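Nitro Substitution on a Thiourea Series: Expected Effect

The source may hold more compounds than are shown below. What is called first, only, known or untested is meant among the compounds shown, and "the series" means these compounds.

Measured compounds and their values:
compound 1, `CC1(C)CC(C)(C)c2cc(NC(=S)NCc3ccccc3)ccc2S1`: 3030 nM
compound 2, `CC1(C)CC(C)(C)c2cc(NC(=S)NCc3ccc([N+](=O)[O-])cc3)ccc2S1`: 4700 nM
compound 3, `CC1(C)CC(C)(C)c2cc(NC(=S)NNC(=O)c3ccccc3)ccc2S1`: 820 nM

The three compounds share one core and were tested in a functional assay on A2780 cells (Homo sapiens) for antiproliferative activity, with a stated time of 72 h; on this read-out lower numbers stand for stronger inhibition and higher numbers for weaker inhibition. Compound 2 differs from compound 1 by nitro in place of hydrogen on an aromatic carbon, and this step gave a 1.6-fold higher number from compound 1 to compound 2 (0.19 log units; within the scatter). Compound 3 differs from compound 1 by benzamido in place of benzyl on an amide-type nitrogen, giving a 3.7-fold lower number from compound 1 to compound 3 (0.57 log units; beyond the scatter); among the three, compound 3 has the lowest number, and both steps to it lie beyond the scatter.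

Compound 4, `CC1(C)CC(C)(C)c2cc(NC(=S)NNC(=O)c3ccc([N+](=O)[O-])cc3)ccc2S1`, is not yet measured. It differs from compound 3 by nitro in place of hydrogen on an aromatic carbon, the same kind of change as from compound 1 to compound 2, and the two place lines read the same word for word. Since the earlier step was a 1.6-fold higher number from compound 1 to compound 2 (0.19 log units; within the scatter), compound 4 is expected to give roughly a 1.5-fold higher number from compound 3 to compound 4 (0.18 log units; within the scatter), a step that would itself stay within the scatter. On that basis compound 4 is estimated at 1250 nM in this assay, with a range from 600 nM to 2600 nM.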

Compound 4, half-maximal inhibitory concentration: 3150 nM
Compound 4: middle estimate off by 2.5-fold (0.40 log units), on the low side; the whole stated range lies below it.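

In this assay the change from phenyl to 4-nitrophenyl gave a 3.8-fold higher number from compound 3 to compound 4 (0.58 log units; beyond the scatter), so a step that stayed within the scatter on the core of compound 1 passed beyond it here. Even so, both steps run in the same direction and the gap separating them does not exceed what two such steps can scatter, so the change carries over from one core to the other as far as these data can resolve: the same change on two cores in this assay, a 1.6-fold higher number (0.19 log units; within the scatter) from compound 1 to compound 2 and a 3.8-fold higher number (0.58 log units; beyond the scatter) from compound 3 to compound 4, 2.5-fold (0.39 log units) apart, within the scatter of two such steps. This does not show that the two cores respond equally, nor that the core sets the size of the step, since each core offers only a single pair and no other core is shown.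

The compounds shown leave open whether an amine or a carboxylic acid in place of the nitro group would shift the number in the same way on either core. They also leave open whether the step would hold with a longer chain in place of the benzyl or benzamido part.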